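A Tert-Butyl to Fluoro Swap Carried onto a Second Core

A few compounds are considered here, and "the series" means these few. Any claim that something is new, unique, unknown or untested is made for them only; others in the source may bear on it.

Compound 1 `CC(C)(C)c1ccc(C(=O)N/N=C/c2cc(I)cc(I)c2O)cc1` and compound 2 `O=C(N/N=C/c1cc(I)cc(I)c1O)c1ccc(F)cc1` share one core, while compound 3 `CC(C)(C)c1ccc(C(=O)NNC(=O)c2cc(I)cc(I)c2O)cc1` and compound 4 `O=C(NNC(=O)c1cc(I)cc(I)c1O)c1ccc(F)cc1` share another; the difference between the two cores is not broken down here. In a functional assay on HepG2 cells (Homo sapiens) for cytotoxicity, with a stated time of 24 h (on this read-out lower numbers stand for stronger inhibition and higher numbers for weaker inhibition), compound 1 gives 41600 nM and compound 2 gives 12100 nM. The change between them is fluoro in place of tert-butyl on an aromatic carbon, and it made a 3.4-fold lower number from compound 1 to compound 2 (0.54 log units; beyond the scatter). Compound 3 stands highest of the three measured numbers in this assay with 87300 nM. The change from compound 3 to compound 4 is fluoro in place of tert-butyl on an aromatic carbon, the same change as before, now made on the other core. Because the step of a 3.4-fold lower number from compound 1 to compound 2 (0.54 log units; beyond the scatter) went beyond the scatter, a step of similar size and direction is expected for compound 4, so that a 3.4-fold lower number from compound 3 to compound 4 (0.53 log units; beyond the scatter) is estimated. On that basis compound 4 is expected to give about 26000 nM in this assay, most likely between 11000 nM and 60000 nM. For the measured compounds named here, only one measured pair carries this change, so the expectation rests on a single step and should be read with that in mind.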

Compound 4, half-maximal inhibitory concentration: 87000 nM
Compound 4: middle estimate off by 3.3-fold (0.52 log units), on the low side; measured number above the stated range.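

In this assay, the step on the second core is a 1.0-fold lower number from compound 3 to compound 4 (0.00 log units; within the scatter), so compound 3 and compound 4 cannot be told apart on this read-out. Swapping tert-butyl for fluoro therefore did not carry over from one core to the other in the way the first pair suggested: the same change on two cores in this assay, a 3.4-fold lower number (0.54 log units; beyond the scatter) from compound 1 to compound 2 and a 1.0-fold lower number (0.00 log units; within the scatter) from compound 3 to compound 4, 3.4-fold (0.53 log units) apart, beyond the scatter of two such steps This shows that, in these four compounds, the result of the swap depends on the core it is made on, but it does not show which feature of the cores is responsible, and one pair on each core cannot describe how the swap behaves across a wider series.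

From the compounds shown here alone, it remains open whether any other group on that aromatic carbon, such as an amine, a carboxylic acid or a longer carbon chain, would shift the number on the core of compound 3. Going by these compounds, it also remains open whether the same swap would give a clear step on the core of compound 3 in a different kind of test.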